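Dichloroacetamide biphenyls: replacing one amide with trifluoromethyl

This account rests on a few compounds, and the source may have more. Where it says the series, first, only, none or still open, it means among the compounds named here.

Measured compounds so far:
compound 1, `O=C(Nc1cccc(-c2cccc(NC(=O)C(Cl)Cl)c2)c1)C(Cl)Cl` — > 50000 nM
compound 2, `Cc1ccc(-c2cccc(NC(=O)C(Cl)Cl)c2)cc1` — 8000 nM
compound 3, `CCOc1ccccc1-c1cc(NC(=O)C(Cl)Cl)cc(-c2ccccc2OCC)c1` — 5090 nM

The read-out throughout is a functional assay on NCI-H460 cells (Homo sapiens) for cytotoxicity, read by MTT assay, with a stated time of 68 h; on this read-out lower numbers stand for stronger inhibition and higher numbers for weaker inhibition. For the measured compounds named here, for compound 1 the value > 50000 nM is a limit of the assay, not a number; compound 1 is the one compound of the three that sits at the limit of > 50000 nM in this assay, at which 1 of the 3 values shown sits. Compound 2 gives 8000 nM and compound 3 gives 5090 nM; these two values lie within the usual scatter of each other, so no order between them is claimed.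

The unmeasured compound 4, `O=C(Nc1cccc(-c2cccc(C(F)(F)F)c2)c1)C(Cl)Cl`, differs from compound 1 in one place: trifluoromethyl in place of ((dichloromethyl)carbonyl)amino on an aromatic carbon. Compound 4 thereby keeps the ((dichloromethyl)carbonyl)amino group on one ring of the shared core and carries a small substituent on the other, as compound 2 does, although with trifluoromethyl rather than methyl. On that likeness, compound 4 is expected to give a number in this assay rather than a limit, close to compound 2 at 8000 nM. The step of an at least 6.2-fold lower number from compound 1 to compound 4 (0.79 log units; beyond the scatter) is therefore expected to run toward stronger inhibition, beyond the scatter. The estimate for compound 4 is 8000 nM, with a range from 2500 nM to 30000 nM.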

Compound 4, half-maximal inhibitory concentration: 30200 nM
Estimate against measurement, compound 4: 3.8-fold (0.58 log units) below; measured number outside the range, above it.
By their numbers in this assay, from the lowest: compounds 3 and 2 (each within the scatter of the next); then compound 4. At a limit, above all of these: compound 1.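

In this assay, for the compounds shown here, trifluoromethyl in place of ((dichloromethyl)carbonyl)amino on an aromatic carbon gives an at least 1.6-fold lower number from compound 1 to compound 4 (0.21 log units; that floor lies within the scatter), the first one-place comparison. Compound 1 gives > 50000 nM, which is a limit of the assay and not a number. Exchanging this one group for trifluoromethyl leads to compound 4, which gives 30200 nM. The change cannot be sized or called a real gain in inhibition beyond its printed floor, because one end of the comparison is a limit: the limit of > 50000 nM in this assay, at which 1 of the 4 values shown sits.

Open at this position is whether an amine, a carboxylic acid or a longer chain in place of the ((dichloromethyl)carbonyl)amino group would give a value like that of compound 4, or whether the outcome is particular to trifluoromethyl. Also open, on these data alone, is what the ((dichloromethyl)carbonyl)amino group remaining on the other ring contributes to the value of compound 4, as the one-place comparison here concerns only the group that leaves.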